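A few compounds are considered here, and "the series" means these few. Any claim that something is new, unique, unknown or untested is made for them only; others in the source may bear on it.

The three compounds measured in a functional assay on B16-F0 cells (Mus musculus) for inhibition, read by CCK-8 assay, with a stated time of 48 h (a higher number here means a weaker inhibitor, a lower number a stronger inhibitor), are these.
Compound 1 `COc1cc(-c2ccnc3cc(-c4ccc(Cl)cc4)nn23)cc(OC)c1OC` gives 4090 nM.
Compound 2 `COc1cc(-c2ccnc3cc(-c4cccc(C#N)c4)nn23)cc(OC)c1OC` gives only a limit, > 10000 nM.
Compound 3 `COc1cc(-c2ccnc3cc(-c4cn(C)c5ccccc45)nn23)cc(OC)c1OC` gives 185 nM.

Compound 2 therefore stands at the weak end of the three; its value is a limit of this assay and not a number (the limit of > 10000 nM in this assay, at which 1 of the 3 values shown sits). Both steps that touch it are bounds for the same reason: the step of an at least 2.4-fold higher number from compound 1 to compound 2 (0.38 log units; beyond the scatter) and the step of an at least 54-fold lower number from compound 2 to compound 3 (1.73 log units; beyond the scatter). These two steps, together with a 22-fold lower number from compound 1 to compound 3 (1.34 log units; beyond the scatter), show that the aryl ring on this carbon of the shared core moves the number over a wide span, with compound 3 far stronger than compound 1 and compound 2.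

Compound 4 `COc1ccc(-c2cc3nccc(-c4cc(OC)c(OC)c(OC)c4)n3n2)cc1N` differs from compound 2 in one place: 3-amino-4-methoxyphenyl in place of 3-cyanophenyl on an aromatic carbon. The new ring is a substituted phenyl, as in compound 1 and compound 2, rather than the bicyclic ring of compound 3, so the large gain seen for compound 3 is not expected to carry over in full. Still, removing the 3-cyanophenyl that set compound 2 below compound 1 is expected to bring a moderate step down, an at least 2.8-fold lower number from compound 2 to compound 4 (0.45 log units; beyond the scatter). Compound 4 is thus estimated at 3500 nM, within 900 nM to 12000 nM, with a real chance that only a limit is returned.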

Compound 4, half-maximal inhibitory concentration: 88 nM
Beside the measured number, compound 4's estimate is 40-fold (1.60 log units) above it, and the stated range ends above it.
By their numbers in this assay, from the lowest: compound 4; then compound 3; then compound 1. At a limit, above all of these: compound 2.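

The result shows that in this assay a single substituted phenyl ring on this carbon can give a strong number, something compound 1 and compound 2 gave no sign of: a 46-fold lower number from compound 1 to compound 4 (1.67 log units; beyond the scatter). The 1-methyl-1H-indol-3-yl of compound 3 had been the only strong group at this position, yet the 3-amino-4-methoxyphenyl goes modestly further, with a 2.1-fold lower number from compound 3 to compound 4 (0.32 log units; beyond the scatter), so the fused two-ring group is not needed for a low number among these compounds. Against the 3-cyanophenyl the change can be read only as a bound, an at least 110-fold lower number from compound 2 to compound 4 (2.05 log units; beyond the scatter), as the value of compound 2 is a limit of the assay and not a number: the limit of > 10000 nM in this assay, at which 1 of the 4 values shown sits.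

The amine and the methoxy group enter together in compound 4, so the compounds shown do not separate what each contributes to these steps. Also open, going by these compounds, is how a 3-aminophenyl or a 4-methoxyphenyl ring alone would read in this assay, and whether a hydroxyl or an acetamide could stand in place of the amine.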